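Shifting a Methyl Group on a Weakly Active Spiro Scaffold

A few compounds are considered here, and "the series" means these few. Any claim that something is new, unique, unknown or untested is made for them only; others in the source may bear on it.

Measured compounds:
Compound 1, `N#CC1=C(N)Oc2c(c3nc4ccccc4nc3c3ccccc23)C12C(=O)N(Cc1cnnn1-c1cccc(Br)c1)c1ccccc12`: > 50000 nM
Compound 2, `Cc1ccc(C)c(-n2nncc2CN2C(=O)C3(C(C#N)=C(N)Oc4c3c3nc5ccccc5nc3c3ccccc43)c3ccccc32)c1`: > 50000 nM

Both measured compounds share one core and differ only in the aryl group carried on an aromatic nitrogen of the triazole. In a functional assay on A549 cells (Homo sapiens) for antiproliferative activity, read by MTT assay, with a stated time of 48 h (a higher number here means a weaker inhibitor, a lower number a stronger inhibitor), compound 1 reaches only the limit of the assay, > 50000 nM. Compound 2 in this assay likewise reaches only a limit, > 50000 nM. The step that the two limits leave unreadable from compound 1 to compound 2 therefore cannot be read, since the limit of > 50000 nM in this assay, at which 2 of the 2 values shown sit, shows that both values sit at the same ceiling rather than at a number.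

Compound 3, `Cc1cc(C)cc(-n2nncc2CN2C(=O)C3(C(C#N)=C(N)Oc4c3c3nc5ccccc5nc3c3ccccc43)c3ccccc32)c1`, has not yet been measured. It differs from compound 2 by 3,5-dimethylphenyl in place of 2,5-dimethylphenyl on an aromatic nitrogen; the two compounds have the same atoms joined differently. Among the compounds with values here, the only measured step, from compound 1 to compound 2, gives no readable size and no direction, so there is nothing in the numbers that would point compound 3 away from the limit in either direction.

Compound 3 is therefore expected to give 60000 nM in this assay, within 20000 nM to 200000 nM, and the expected step that the limit leaves unreadable from compound 2 to compound 3 is most likely again hidden behind the assay ceiling.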

Compound 3, half-maximal inhibitory concentration: > 50000 nM
Compound 3 gave a limit, no number; the forecaster's own chance of this, stated with the estimate: 85%; the middle value is on the limit's open side.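

In this assay compound 3 gives > 50000 nM as a limit, not a number. Within the data shown here, no step among compound 1, compound 2 and compound 3 can be read, because all three stop at the same ceiling: the limit of > 50000 nM in this assay, at which 3 of the 3 values shown sit.

The compounds shown leave open how 3,5-dimethylphenyl and 2,5-dimethylphenyl compare, and whether any aryl group on the shared core gives a measurable value.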